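This account rests on a few compounds, and the source may have more. Where it says the series, first, only, none or still open, it means among the compounds named here.

Measured so far in an ADME assay on MDBK cells (Bos taurus) for cytotoxicity; on this read-out lower numbers stand for higher toxicity in this test and higher numbers for lower toxicity in this test:
- compound 1 `CCn1ccc2nc(-c3ccccc3)nc-2c1`: > 100000 nM
- compound 2 `CC(C)=CCn1ccc2nc(-c3ccccc3)nc-2c1`: > 100000 nM

Both entries are limits of the assay and not numbers. Compound 2 therefore has no exact position, and its > 100000 nM is only a limit. The two measured compounds share (the limit of > 100000 nM in this assay, at which 2 of the 2 values shown sit).

Compound 3 `c1ccc(-c2nc3ccn(CC4CCCCC4)cc-3n2)cc1` is next, with cyclohexyl in place of 2-methylprop-1-en-1-yl on a saturated chain carbon bound to an aromatic nitrogen.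

Among the measured compounds shown here, the only measured step at this place is a step that the two limits leave unreadable from compound 1 to compound 2, so its size gives no guide. With nothing else to go on, no step beyond the scatter is expected in this assay. The expected step is a number no higher from compound 2 to compound 3 (the limit leaves the size open). For compound 3 the estimated value is 100000 nM, with an expected range from 40000 nM to 200000 nM.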

Compound 3, half-maximal cytotoxic concentration: > 100000 nM
Compound 3 ended at the assay's limit; the forecaster's own chance of this, stated with the estimate: 70%; the middle value lies on the limit itself.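

No step can be read among compound 1, compound 2 and compound 3, since each entry is a limit of the assay and not a number: the limit of > 100000 nM in this assay, at which 3 of the 3 values shown sit.

The compounds shown leave open how the side chains on the saturated chain carbon bound to an aromatic nitrogen compare in this assay, since none of the three has an exact value.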